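The source may report more compounds than this note shows. Statements on the series, on what has been measured and on what is new or still open speak of the compounds shown alone.

Working notes on the series. Compound 1 `CC#C[C@H]1CN(S(=O)(=O)c2ccc(N)nc2)CCN1c1ccc(C(O)(CC#N)C(F)(F)F)cc1` is the reference point; in an ADME assay (liver) for metabolic stability, with Liver microsome (Rattus norvegicus) as the target, using microsomes and NADPH, with a stated time of 30 min (on this read-out higher numbers stand for fast clearance and lower numbers for slow clearance), compound 1 gives 57 mL.min-1.g-1. Two measured relatives sit alongside it. Compound 2 `CC#C[C@H]1CN(S(=O)(=O)c2ccc(N)nc2)CCN1c1ccc(C(O)(C(F)(F)F)C(F)(F)F)cn1` gives 42 mL.min-1.g-1 in this assay, and compound 3 `CC#C[C@H]1CN(S(=O)(=O)c2ccc(N)nc2)CCN1c1ccc(S(N)(=O)=O)cc1` gives 30 mL.min-1.g-1. On the numbers shown, compound 1 carries the highest value of the three, but neither gap clears the scatter: the values of compound 1 and compound 2 lie close together, and the one single-point step that is defined, a 1.9-fold lower number from compound 1 to compound 3 (0.28 log units; within the scatter), is likewise within the scatter.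

The unmeasured compound is compound 4 `C#CCC(O)(c1ccc(N2CCN(S(=O)(=O)c3ccc(N)nc3)C[C@@H]2C#CC)cc1)C(F)(F)F`. Relative to compound 1 the change is ethynyl in place of cyano on a saturated chain carbon, two bonds along the chain from an aromatic carbon and an oxygen on a saturated carbon. Among the compounds with values here, no measured step touches this exact swap. Within the data shown here, the only step that alters the same side chain of the core of compound 1 is a 1.9-fold lower number from compound 1 to compound 3 (0.28 log units; within the scatter), which replaced the whole group rather than its terminus and still produced no movement beyond the scatter. A smaller edit at the tip of that chain therefore gives no grounds to expect a step beyond the scatter in either direction. Compound 4 is estimated at 60 mL.min-1.g-1, with a range of 35 mL.min-1.g-1 to 105 mL.min-1.g-1. That expectation corresponds to a step of a 1.1-fold higher number from compound 1 to compound 4 (0.02 log units; within the scatter).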

Compound 4, intrinsic clearance in microsomes: 59 mL.min-1.g-1
Estimate against measurement, compound 4: 1.0-fold (0.01 log units) above; the measured number falls inside the stated range.
By their numbers in this assay, from the lowest: compounds 3, 2, 1 and 4 (each within the scatter of the next).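

Within the data shown here, this is the first step confined to the tip of the side chain: in this assay, ethynyl in place of cyano on a saturated chain carbon gives a 1.0-fold higher number from compound 1 to compound 4 (0.01 log units; within the scatter), so removing the hydrogen-bond acceptor counted on cyano does not produce a step beyond the scatter at this place. The whole-group exchange on the aromatic carbon now has a second reading, a 2.0-fold higher number from compound 3 to compound 4 (0.29 log units; within the scatter), and like a 1.9-fold lower number from compound 1 to compound 3 (0.28 log units; within the scatter) it stays within the scatter, so neither the terminal swap nor either whole-group exchange separates these three compounds on this read-out. Nothing among the data shown speaks to a reason for this result.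

As far as these compounds go, whether a primary amine or a carboxylic acid in place of ethynyl, or a chain longer than propargyl, would give a step beyond the scatter at this place remains open. Also open, from the compounds shown here alone, is whether the cyanomethyl to propargyl exchange would read the same way on a core other than that of compound 1, or in any assay other than this assay.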